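A few compounds are considered here, and "the series" means these few. Any claim that something is new, unique, unknown or untested is made for them only; others in the source may bear on it.

Measured compounds:
- compound 1, `COc1ccc(CN(c2cc(OC)c(OC)c(OC)c2)S(=O)(=O)c2ccc(OC)c(OC)c2)cc1`, in a functional assay on MGC-803 cells (Homo sapiens) for inhibition, read by MTT assay, with a stated time of 48 h (on this read-out lower numbers stand for stronger inhibition and higher numbers for weaker inhibition), gives 8310 nM
- compound 2, `COc1cc(N(Cc2nc3ccccc3[nH]2)S(=O)(=O)c2ccc(F)cc2)cc(OC)c1OC`, in this assay gives 5680 nM

Compound 2 holds the lowest of the two numbers, and its nearest neighbour is compound 1, whose number lies within the usual scatter of repeated measurements, so the two cannot be told apart on these data. Compound 3, `COc1cc(N(Cc2nc3ccccc3[nH]2)C(=O)c2ccc(Br)cc2)cc(OC)c1OC`, has not yet been measured. It differs from compound 2 in one place: (4-bromophenyl)carbonyl in place of (4-fluorophenyl)sulfonyl on a nitrogen on an aromatic ring. Within the data shown here, no step between two measured compounds of this kind is available, so nothing measured shows how this exchange shifts the result. Among the measured compounds shown here, the two known numbers sit close together despite their different groups on the nitrogen and their different groups on the shared core, which suggests that a single exchange of this sort need not move the number far. Compound 3 is therefore expected to give a number that stays near that of compound 2, with a step of a 1.1-fold lower number from compound 2 to compound 3 (0.06 log units; within the scatter) in this assay, in either direction but not clearly beyond the scatter. The estimate for compound 3 is 5000 nM, within a range from 1500 nM to 20000 nM.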

Compound 3, half-maximal inhibitory concentration: 14600 nM
For compound 3 the middle estimate is 2.9-fold (0.47 log units) below the measured one; the measured number falls inside the stated range.
By their numbers in this assay, from the lowest: compounds 2, 1 and 3 (each within the scatter of the next, the first and the last beyond it).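

Among these compounds, replacing (4-fluorophenyl)sulfonyl with (4-bromophenyl)carbonyl on the nitrogen on an aromatic ring gives a 2.6-fold higher number from compound 2 to compound 3 (0.41 log units; beyond the scatter) in this assay, the first measured step at this position. It shows that the read-out responds to this exchange on the shared core, though only modestly, and that the sulfonyl compound of this pair has the lower number. No measurement shown here offers an explanation for the step.

The exchange alters two features at once, the carbonyl for the sulfonyl and the bromine for the fluorine, so the compounds shown leave open which of the two carries the step; (4-fluorophenyl)carbonyl or (4-bromophenyl)sulfonyl on the same nitrogen would separate them. They also leave open how this position would respond to a group with no aromatic ring, such as methylsulfonyl or acetyl, or to a phenylsulfonyl group bearing an amine or a carboxylic acid in place of the halogen.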